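The source may hold more compounds than are shown below. What is called first, only, known or untested is meant among the compounds shown, and "the series" means these compounds.

Working notes on the acyl-urea hydrazone series.

Of the compounds shown here, three have numbers so far. Compound 1 `CN(C(=O)NC(=O)c1ccc([N+](=O)[O-])cc1)c1nc(C(F)(F)F)c(C(=O)N/N=C/c2cccc(C(F)(F)F)c2)s1` gives 4.12 ug/mL in a functional assay on HeLa cells (Homo sapiens) for inhibition, read by MTT assay, with a stated time of 72 h; a higher number here means a weaker inhibitor, a lower number a stronger inhibitor. Compound 2 `CN(C(=O)NC(=O)c1cccc([N+](=O)[O-])c1)c1nc(C(F)(F)F)c(C(=O)N/N=C/c2ccccc2C(F)(F)F)s1` gives 4.15 ug/mL in this assay, which is the second highest of the three numbers and lies within the scatter of compound 1. Compound 3 `Cc1nc(N(C)C(=O)NC(=O)c2ccc(Cl)cc2Cl)sc1C(=O)N/N=C/c1ccc(C(F)(F)F)cc1` gives 20.3 ug/mL in this assay; it sits beyond the scatter from compound 2, but differs from it in more than one place, so its two values show only that it is the weaker of the pair.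

Compound 4 `CN(C(=O)NC(=O)c1ccc(F)c(F)c1)c1nc(C(F)(F)F)c(C(=O)N/N=C/c2ccccc2C(F)(F)F)s1` is not yet measured. Relative to compound 2 it carries 3,4-difluorophenyl in place of 3-nitrophenyl on a carbonyl carbon. Among the compounds with values here, no measured pair in the set isolates this change, and nothing here speaks to how a 3,4-difluorophenyl behaves on that carbonyl carbon against a 3-nitrophenyl. The two compounds with a nitrophenyl on that carbonyl, compound 1 and compound 2, lie together, which gives a stable anchor but no direction.

The step from compound 2 to compound 4 is expected to be small, a 1.4-fold higher number from compound 2 to compound 4 (0.16 log units; within the scatter), and within or close to the scatter, leaning slightly toward a higher number. Compound 4 is therefore estimated at 6 ug/mL in this assay, with a range from 2.5 ug/mL to 15 ug/mL.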

Compound 4, half-maximal inhibitory concentration: 9.24 ug/mL
Compound 4: the middle estimate sits 1.5-fold (0.19 log units) below what was measured, and the stated range covers the measured number.
By their numbers in this assay, from the lowest: compounds 1 and 2 (each within the scatter of the next); then compound 4; then compound 3.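

In this assay, within the data shown here, 3,4-difluorophenyl in place of 3-nitrophenyl on a carbonyl carbon gives a 2.2-fold higher number from compound 2 to compound 4 (0.35 log units; beyond the scatter), the first step that isolates a single change. This shows that the group on this carbonyl carbon can shift the number while the rest of the molecule stays fixed, and that, of these two groups, the 3-nitrophenyl gives the stronger inhibitor on the background of compound 2, although the margin is modest. No measurement at hand bears on the origin of this step, so it stands as an observation only.

A single pair cannot show whether the shift follows the loss of the nitro group or the arrival of the two fluorines, and a plain phenyl or a pyridine ring on the same carbonyl carbon would be needed to place both groups on a wider scale. Going by these compounds, whether the step carries over to other backgrounds also remains open, as compound 1 and compound 3 each differ from compound 4 in more than one place.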